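Swapping the aryl group on compound 2: what to expect

This account rests on a few compounds, and the source may have more. Where it says the series, first, only, none or still open, it means among the compounds named here.

Three compounds share one core and differ only in the aryl group on a carbon with a double bond to nitrogen: compound 1 `CN(C)CCn1cnnc1-c1cc(Oc2ccc(NC(=O)N/N=C/c3ccc(F)cc3Cl)cc2F)ccn1`, compound 2 `CN(C)CCn1cnnc1-c1cc(Oc2ccc(NC(=O)N/N=C/c3cccc(Cl)c3Cl)cc2F)ccn1` and compound 3 `CN(C)CCn1cnnc1-c1cc(Oc2ccc(NC(=O)N/N=C/c3cc(Br)c(O)c(Br)c3)cc2F)ccn1`. In a functional assay on U-87MG ATCC cells (Homo sapiens) for cytotoxicity, read by MTT assay, with a stated time of 72 h (on this read-out higher numbers stand for weaker inhibition and lower numbers for stronger inhibition), compound 1 gives 1210 nM. Compound 2 gives 13200 nM in this assay, the highest of the two numbers shown; its nearest neighbour is compound 1, the move to 2,3-dichlorophenyl having produced an 11-fold higher number from compound 1 to compound 2 (1.04 log units; beyond the scatter). Compound 3 does not yield a number but only a limit of this assay, > 100000 nM, namely (the limit of > 100000 nM in this assay, at which 1 of the 3 values shown sits).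

Compound 4 `Cc1cc(/C=N/NC(=O)Nc2ccc(Oc3ccnc(-c4nncn4CCN(C)C)c3)c(F)c2)cc(C)c1O` has not yet been measured. It differs from compound 2 by 4-hydroxy-3,5-dimethylphenyl in place of 2,3-dichlorophenyl on a carbon with a double bond to nitrogen.

Among the measured compounds shown here, the step that bears most directly on this change is the one to compound 3, which carries the same 4-hydroxy substituent within a 3,5-dibromo-4-hydroxyphenyl and showed an at least 7.5-fold higher number from compound 2 to compound 3 (0.87 log units; beyond the scatter); from compound 1 the same group gave an at least 82-fold higher number from compound 1 to compound 3 (1.91 log units; beyond the scatter). The 4-hydroxy-3,5-dimethylphenyl of compound 4 keeps that hydroxy pattern, so a large rise in the number, possibly to the limit again, is expected. Compound 4 is therefore estimated at 60000 nM, within 15000 nM to 200000 nM. That estimate corresponds to an expected 4.5-fold higher number from compound 2 to compound 4 (0.66 log units; beyond the scatter).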

Compound 4, half-maximal inhibitory concentration: 7710 nM
For compound 4 the middle estimate is 7.8-fold (0.89 log units) above the measured one, outside the stated range (below it).
By their numbers in this assay, from the lowest: compound 1; then compounds 4 and 2 (each within the scatter of the next). At a limit, above all of these: compound 3.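

In this assay, a 4-hydroxy group on this aryl ring does not by itself go with the loss seen for compound 3: the change from 2,3-dichlorophenyl gives a 1.7-fold lower number from compound 2 to compound 4 (0.23 log units; within the scatter) and so leaves the two compounds indistinguishable, while the comparison with 2-chloro-4-fluorophenyl gives a 6.4-fold higher number from compound 1 to compound 4 (0.80 log units; beyond the scatter) and keeps that group clearly ahead. What matters between the two hydroxy-bearing groups is the pair of other substituents, since exchanging 3,5-dibromo-4-hydroxyphenyl for 4-hydroxy-3,5-dimethylphenyl gives an at least 12-fold lower number from compound 3 to compound 4 (1.11 log units; beyond the scatter) and so recovers most of what the dibromo group appeared to lose. On these data alone, compound 3 is held only as a limit of the assay, so the full size of that step stays unknown: the limit of > 100000 nM in this assay, at which 1 of the 4 values shown sits.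

As far as these compounds go, what the 4-hydroxy group contributes on its own remains open, and a methoxy group in its place, or a 3,5-dimethylphenyl group with no oxygen at all, would speak to that. From the compounds shown here alone, it also remains open whether the bromine atoms are special among halogens, which a 3,5-dichloro-4-hydroxyphenyl group at this carbon would address.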